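Cyano to fluoro on a shared biaryl arm, two cores

This account rests on a few compounds, and the source may have more. Where it says the series, first, only, none or still open, it means among the compounds named here.

The study compares four compounds that share the same overall build and differ in two places: the core, and one substituent on the outer ring of the biaryl arm. Compound 1 `Cc1cc(-c2ccc(C#N)cc2)cc(C)c1Oc1nc(Nc2ccc(C#N)c(F)c2)nc2ccsc12` and compound 2 `Cc1cc(-c2ccc(C#N)cc2)cc(C)c1Oc1nc(Nc2ccc(C#N)c(F)c2)nc2sccc12` are made of the same atoms joined differently; how their two cores differ is not broken down here. Compound 3 `Cc1cc(-c2ccc(F)cc2)cc(C)c1Oc1nc(Nc2ccc(C#N)c(F)c2)nc2ccsc12` is compound 1 with one change: fluoro in place of cyano on an aromatic carbon. Compound 4 `Cc1cc(-c2ccc(F)cc2)cc(C)c1Oc1nc(Nc2ccc(C#N)c(F)c2)nc2sccc12`, not yet measured, stands to compound 2 exactly as compound 3 stands to compound 1: fluoro in place of cyano on an aromatic carbon. The two changes are the same change, made on the two cores.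

In a toxicity assay on MT4 cells (Homo sapiens) for cytotoxicity, read by MTT assay, with a stated time of 5 days (on this read-out lower numbers stand for higher toxicity in this test and higher numbers for lower toxicity in this test), compound 1 gives 71500 nM, and compound 3 gives 97300 nM. The step between them is a 1.4-fold higher number from compound 1 to compound 3 (0.13 log units; within the scatter). Compound 2 gives only a limit of this assay, > 254000 nM. That limit is recorded as the limit of > 254000 nM in this assay, at which 1 of the 3 values shown sits.

Because a 1.4-fold higher number from compound 1 to compound 3 (0.13 log units; within the scatter) leaves the read-out essentially where it was, the same change on the core of compound 2 is expected to behave alike, so compound 4 is estimated at 300000 nM, with a range from 180000 nM to 600000 nM. The expected step from compound 2 is a step that the limit leaves unreadable from compound 2 to compound 4, and since compound 2 already sits at a limit, compound 4 is expected most likely to return only a limit as well.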

Compound 4, half-maximal cytotoxic concentration: 28900 nM
Compound 4: the middle estimate sits 10-fold (1.02 log units) above what was measured; the whole stated range lies above it.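

In this assay, the swap of 4-cyanophenyl to 4-fluorophenyl gives an at least 8.7-fold lower number from compound 2 to compound 4 (0.94 log units; beyond the scatter), a lower number that here stands for higher toxicity in this test, whereas the same swap on the other core gives a 1.4-fold higher number from compound 1 to compound 3 (0.13 log units; within the scatter). Within this set of four compounds, the change therefore does not carry over unaltered from one core to the other, and what it does to the read-out depends on the core that bears it: the same change on two cores in this assay, a 1.4-fold higher number (0.13 log units; within the scatter) from compound 1 to compound 3 and an at least 8.7-fold lower number (0.94 log units; beyond the scatter) from compound 2 to compound 4, at least 11-fold (1.07 log units) apart, beyond the scatter of two such steps. Compound 2 is recorded only as a limit, > 254000 nM, so the full size of its step remains unread, and one change on two cores does not show why the steps part or which feature of the cores is responsible.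

From the compounds shown here alone, it remains open whether other groups placed para to the large group on the outer ring, such as an amine or a methoxy group, would leave the read-out of this assay in place on one core and move it on the other, as fluoro does here. Going by these compounds, whether the same split would appear on any core beyond these two also remains open.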